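The compounds below may be only part of what the source reports. "The series", "measured", "known", "first", "only" and "open" are said of these compounds alone.

Measured compounds and their values in a functional assay on HCT-116 cells (Homo sapiens) for cytotoxicity, read by MTT assay, with a stated time of 72 h; on this read-out higher numbers stand for weaker inhibition and lower numbers for stronger inhibition:
compound 1, `Cc1cc(-c2ccccc2)n(/C(N)=N/S(=O)(=O)c2cc(C)c(Cl)cc2SCc2ccccc2C(F)(F)F)n1`, 25000 nM
compound 2, `Cc1cc(S(=O)(=O)/N=C(\N)n2nccc2-c2ccccc2)c(SCc2cccc(Cl)c2)cc1Cl`, 7000 nM
compound 3, `Cc1ccc(CSc2cc(Cl)c(C)cc2S(=O)(=O)/N=C(\N)n2nccc2-c2ccccc2)cc1`, 14000 nM

Compound 3 sits second highest of the three numbers in this assay. Its nearest neighbour is compound 1, which gives 25000 nM, a gap within the scatter; its furthest is compound 2, which gives 7000 nM, also within the scatter. On these numbers, then, the three compounds cannot be told apart.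

The next compound, compound 4 with `Cc1cc(S(=O)(=O)/N=C(\N)n2nccc2-c2ccccc2)c(SCc2ccccc2C(F)(F)F)cc1Cl`, differs from compound 3 in one place: 2-(trifluoromethyl)phenyl in place of 4-methylphenyl on a saturated chain carbon bound to a sulfur. Among the compounds with values here, the only measured step of the same kind, a swap of one aryl group for another on the saturated chain carbon bound to a sulfur, is a 2.0-fold higher number from compound 2 to compound 3 (0.30 log units; within the scatter). That step stayed within the scatter, so the group on that chain carbon has so far left the number in this assay essentially unchanged. Compound 1 carries the same 2-(trifluoromethyl)benzyl group on a different core and gives 25000 nM, a number of the same order as compound 3.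

For compound 4 the step from compound 3 is therefore expected to be small, a 1.3-fold higher number from compound 3 to compound 4 (0.11 log units; within the scatter), with no clear direction beyond the scatter. Compound 4 is estimated to give 18000 nM in this assay, within a range from 7000 nM to 45000 nM.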

Compound 4, half-maximal inhibitory concentration: 16000 nM
Compound 4: the middle estimate sits 1.1-fold (0.05 log units) above what was measured, within the range that was stated.
By their numbers in this assay, from the lowest: compounds 2, 3, 4 and 1 (each within the scatter of the next, the first and the last beyond it).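

In this assay, 2-(trifluoromethyl)phenyl in place of 4-methylphenyl on the saturated chain carbon bound to a sulfur gives a 1.1-fold higher number from compound 3 to compound 4 (0.06 log units; within the scatter) and so adds a second swap at this position that stays within the scatter. Set against 3-chlorophenyl, the same group gives a 2.3-fold higher number from compound 2 to compound 4 (0.36 log units; beyond the scatter) and this is the first step at this position to pass the scatter, although only modestly, so the aryl group here is not entirely without effect on the number. Compound 4 also allows a look at a change elsewhere on the molecule, since hydrogen in place of methyl on an aromatic carbon gives a 1.6-fold lower number from compound 1 to compound 4 (0.19 log units; within the scatter) and that change, with the 2-(trifluoromethyl)benzyl group held constant, leaves the two numbers within the scatter of each other.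

Nothing given here accounts for any of these steps. Still open, on these data alone, is whether a group of another kind on that chain carbon, such as a longer alkyl chain, or an aryl ring carrying an amine or a carboxylic acid, would shift the number by more than these modest steps.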